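Azaindole carboxamide in place of a thienopyridine amide

A few compounds are considered here, and "the series" means these few. Any claim that something is new, unique, unknown or untested is made for them only; others in the source may bear on it.

Compound 1 `O=C(NCc1ccc(S(=O)(=O)c2ccccc2)cc1)c1cc2ncccc2s1`: 400 nM
Compound 2 `O=C(NCc1ccc(S(=O)(=O)c2ccc(F)cc2)cc1)c1cc2cnccc2[nH]1`: 17 nM

Of the compounds shown here, two have been measured in an assay for inhibition of Nicotinamide phosphoribosyltransferase (Homo sapiens), read by mass spectrometry, with stated times of 15 min and 30 min; on this read-out lower numbers stand for stronger inhibition and higher numbers for weaker inhibition. Compound 1 gives 400 nM and stands highest of the two numbers. The nearest is compound 2, which in this assay gives 17 nM, a gap beyond the scatter. Compound 2 differs from compound 1 in more than one place, so its two values are only a hint of where a bicyclic amide with a hydrogen-bond donor can reach.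

Compound 3 `O=C(NCc1ccc(S(=O)(=O)c2ccccc2)cc1)c1c[nH]c2ccncc12` is the next candidate. It changes compound 1 in one place: a group of 9 heavy atoms (7 carbon, 2 nitrogen; one five-membered aromatic ring with 1 hetero atom, one six-membered aromatic ring with 1 hetero atom) in place of a group of 9 heavy atoms (7 carbon, 1 nitrogen, 1 sulfur; one five-membered aromatic ring with 1 hetero atom, one six-membered aromatic ring with 1 hetero atom), on a carbonyl carbon. Going by the values given here, no single step between measured compounds matches this change, so the expectation rests on compound 2, whose value of 17 nM shows that a related bicyclic with one hydrogen-bond donor and one acceptor can sit well below compound 1. Compound 3 is expected to improve on compound 1, with the step of a 4.4-fold lower number from compound 1 to compound 3 (0.65 log units; beyond the scatter) estimated to be beyond the scatter but smaller than the gap to compound 2. The estimate for compound 3 is 90 nM, with a range from 20 nM to 400 nM.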

Compound 3, half-maximal inhibitory concentration: 1900 nM
For compound 3 the middle estimate is 21-fold (1.32 log units) below the measured one; measured number above the stated range.
By their numbers in this assay, from the lowest: compound 2; then compound 1; then compound 3.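

In this assay, going by these compounds alone, the replacement on the carbonyl carbon whose other neighbour is the amide-type nitrogen brings a 4.8-fold higher number from compound 1 to compound 3 (0.68 log units; beyond the scatter), the first reading of a single change at this place. The two bicyclic groups match in heavy-atom count and in ring sizes, and they differ in their atoms and their arrangement, with the entering group carrying 1 hydrogen-bond donor and the leaving group 0, so this place responds to more than the size and ring types of the group; in this pair, gaining the donor comes with a higher number, not a lower one. No measurement shown here accounts for the rise, and compound 2 differs from compound 3 in more than one place, so its value cannot be set against this step.

Going by these compounds, what stays open is how much of the step belongs to the sulfur-for-nitrogen exchange and how much to the way the two rings are joined to the carbonyl carbon. Also open, on these data alone, is how this place would respond to a bicyclic group bearing an amine or a carboxylic acid, and whether the step holds when the sulfonyl-bound phenyl ring carries a fluorine.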